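One added methyl on compound 1

This account rests on a few compounds, and the source may have more. Where it says the series, first, only, none or still open, it means among the compounds named here.

Measured so far in an ADME assay on microsomes from liver (Homo sapiens) for metabolic stability, read by LC-MS, using NADPH, with stated times of 10 min and 30 min (on this read-out lower numbers stand for slow clearance and higher numbers for fast clearance), for two compounds:
- compound 1 `O=C1c2ccc(Cl)cc2CN1c1cccnc1` gives 12.8 mL/min/kg as a number
- compound 2 `CC(=O)N[C@@H]1CCCc2c1cncc2N1C(=O)c2ccc(Cl)cc2[C@@H]1C` gives < 3.5 mL/min/kg as a limit

For the measured compounds named here, compound 1 stands at 12.8 mL/min/kg as the only exact number. For compound 2 the reading < 3.5 mL/min/kg is a limit of the assay, not a number.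

Compound 3 `CC1c2cc(Cl)ccc2C(=O)N1c1cccnc1` differs from compound 1 by methyl in place of hydrogen on a saturated ring carbon in one place: methyl in place of hydrogen on a saturated ring carbon. Going by the values given here, no measured pair shows this change alone, so in this assay only a small step within the scatter, in no firm direction, is expected. The estimated move is a 1.1-fold lower number from compound 1 to compound 3 (0.03 log units; within the scatter) at most a modest one. For compound 3 the expected clearance is 12 mL/min/kg with a range from 6 mL/min/kg to 24 mL/min/kg as an estimate.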

Compound 3, clearance: 12.2 mL/min/kg
Compound 3: middle estimate off by 1.0-fold (0.01 log units), on the low side, within the range that was stated.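

In this assay, placing a methyl on this saturated ring carbon, next to the ring nitrogen, gives a 1.0-fold lower number from compound 1 to compound 3 (0.02 log units; within the scatter), so the two clearance values lie within the usual scatter of each other. This holds only for this one group at this one place on the core of compound 1. Nothing measured here offers an explanation for this result.

Still open, on these data alone, is whether a longer chain such as ethyl, or a different kind of group such as an amine or a hydroxyl, at this same carbon would also leave clearance within the scatter.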